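The source may hold more compounds than are shown below. What is called first, only, known or untested is meant among the compounds shown, and "the series" means these compounds.

Compound 2 `COc1cc(-c2nn(-c3cccc(NC(=O)c4cccc(C(F)(F)F)c4)c3)cc2-c2ccncc2)ccc1Cl` is one of three close relatives measured here, and of those three only compound 3 returned an actual number. In a functional assay on KM12 cells (Homo sapiens) for inhibition, read by sulforhodamine B assay, with a stated time of 48 h (a lower number here means a stronger inhibitor of growth, a higher number a weaker inhibitor of growth), compound 2 gives > 50000 nM, which is a limit of the assay rather than a measured value. Compound 4 `COc1cc(-c2nn(-c3cccc(NC(=O)c4ccccc4)c3)cc2-c2ccncc2)ccc1Cl` differs from it by hydrogen in place of trifluoromethyl on an aromatic carbon. Among the measured compounds shown here, one measured step bears on this change, running in the opposite direction. Compound 1 `O=C(Nc1cccc(-n2cc(-c3ccncc3)c(-c3ccc(Cl)c(O)c3)n2)c1)Nc1cccc(C(F)(F)F)c1` gives > 32500 nM, also a limit. Compound 3 `O=C(Nc1cccc(-n2cc(-c3ccncc3)c(-c3ccc(Cl)c(O)c3)n2)c1)Nc1cc(C(F)(F)F)cc(C(F)(F)F)c1` gives 1430 nM, so that an at least 22-fold lower number from compound 1 to compound 3 (1.35 log units; beyond the scatter). Removing the trifluoromethyl is accordingly expected to leave compound 4 no stronger than compound 2, most likely as another limit, and the expected step reads a step that the limit leaves unreadable from compound 2 to compound 4. Compound 4 is estimated at 70000 nM, within 25000 nM to 250000 nM.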

Compound 4, concentration for total growth inhibition: > 100000 nM
Compound 4: no number, only a limit; the forecaster's own chance of this, stated with the estimate: 85%; middle value at least 1.4-fold (0.15 log units) away from the limit.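

Compound 2 and compound 4 each return only a limit, not a number, and the step between them cannot be read. On these data alone, whether losing the trifluoromethyl changes growth inhibition in this pair remains open.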